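The source may report more compounds than this note shows. Statements on the series, on what has been measured and on what is new or still open speak of the compounds shown alone.

Of the compounds shown here, two have been measured in a functional assay on MGC-803 cells (Homo sapiens) for cytotoxicity, read by MTT assay, with a stated time of 48 h; on this read-out higher numbers stand for weaker inhibition and lower numbers for stronger inhibition. Compound 1 `CC[N+](C)(CC)CC(=O)N1N=C(C)CC1c1ccccc1OC` gives 3320 nM, whereas compound 2 `O=C(c1ccccc1)N1N=C(c2cc3ccccc3oc2=O)CC1c1ccccc1` gives 12700 nM, the higher of the two numbers shown. Compound 3 `Cc1ccc(C(=O)N2N=C(c3cc4ccccc4oc3=O)CC2c2ccccc2)cc1` departs from compound 2 in a single place: methyl in place of hydrogen on an aromatic carbon. Among the compounds with values here, no step between measured compounds is available to gauge this change, so only a small shift, in either direction and within the scatter, is expected. Compound 3 is accordingly estimated to give 10000 nM, with a range from 4000 nM to 30000 nM. The expected change is a 1.3-fold lower number from compound 2 to compound 3 (0.10 log units; within the scatter).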

Compound 3, half-maximal inhibitory concentration: 31300 nM
Beside the measured number, compound 3's estimate is 3.1-fold (0.50 log units) below it; the measured number lies above the stated range.
By their numbers in this assay, from the lowest: compound 1; then compound 2; then compound 3.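

In this assay, within the data shown here, methyl in place of hydrogen on an aromatic carbon, para to a large group, gives a 2.5-fold higher number from compound 2 to compound 3 (0.39 log units; beyond the scatter) and is the first change that can be read in one place. It shows that this position responds to a single added carbon, and here toward weaker inhibition, so phenyl to 4-methylphenyl is not a silent change. Nothing available explains the shift. As far as these compounds go, whether fluorine, an amine or a carboxylic acid on the same carbon would move the number in the same direction stays open, as does the effect of methyl on another carbon of that ring.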